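Removing a Chloro Group From Two Weakly Active Scaffolds

The source may report more compounds than this note shows. Statements on the series, on what has been measured and on what is new or still open speak of the compounds shown alone.

Compound 1 `O=c1cc(CSc2nc3ccccc3s2)oc2ccccc12`: in a functional assay on MDA-MB-435S cells (Homo sapiens) for cytotoxicity, read by MTT assay, with a stated time of 72 h (on this read-out lower numbers stand for stronger inhibition and higher numbers for weaker inhibition), compound 1 gives > 25000 nM, which is a limit of the assay rather than a number.
Compound 2 `Cc1cc(C)nc(SCc2cc(=O)c3cc(Cl)ccc3o2)n1`: in this assay compound 2 gives > 25000 nM, again only a limit.
Compound 3 `O=c1cc(CSc2nc3ccccc3s2)oc2ccc(Cl)cc12`: in this assay compound 3 gives > 25000 nM, once more a limit.

All three measured values sit at the limit of > 25000 nM in this assay, at which 3 of the 3 values shown sit, so none of them is a number that can be set against another. Compound 3 and compound 1 differ in one place, (hydrogen in place of chloro on an aromatic carbon), and the step between them is a step that the two limits leave unreadable from compound 3 to compound 1; with a limit at both ends its size is simply not readable. Compound 2 carries a chloro group on a different core than compound 3; the difference between the two cores is not broken down here.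

Compound 4 `Cc1cc(C)nc(SCc2cc(=O)c3ccccc3o2)n1` has not yet been measured. It differs from compound 2 by hydrogen in place of chloro on an aromatic carbon, the same change that leads from compound 3 to compound 1, at a place described in the same words. In this assay the step from compound 2 to compound 4 is expected to be a step that the limit leaves unreadable from compound 2 to compound 4, resting on the observation that the matching step from compound 3 to compound 1 left both compounds at the limit, a step that the two limits leave unreadable from compound 3 to compound 1. Compound 4 is therefore estimated to give 40000 nM, most likely reported only as a limit again, with an expected range from 15000 nM to 150000 nM.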

Compound 4, half-maximal inhibitory concentration: > 25000 nM
Compound 4 ended at the assay's limit; the forecaster's own chance of this, stated with the estimate: 85%; the middle value is on the limit's open side.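

In this assay compound 4 gives > 25000 nM as a limit of the assay and not a number. For the compounds shown here, compound 2 also sits at a limit, so the step between compound 2 and compound 4 cannot be read, and this result yields no new step. The compounds shown leave open whether hydrogen in place of chloro changes activity on either core, as all values remain at one limit: the limit of > 25000 nM in this assay, at which 4 of the 4 values shown sit.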